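The source may report more compounds than this note shows. Statements on the series, on what has been measured and on what is new or still open speak of the compounds shown alone.

Measured compounds:
- compound 1 `Cc1nc(-c2ccccc2)c(C(=O)N2CCN(c3cccc(Cl)c3)CC2)o1`: 39.2 nM
- compound 2 `CC(=O)Nc1cccc(-c2nc(C)oc2C(=O)N2CCN(c3cccc(Cl)c3)CC2)c1`: 208 nM
- compound 3 `Cc1nc(-c2ccccc2Cl)c(C(=O)N2CCN(c3cccc(Cl)c3)CC2)o1`: 132 nM

In a functional assay on HL-60 cells (Homo sapiens) for inhibition, read by MTT assay, with a stated time of 72 h (on this read-out higher numbers stand for weaker inhibition and lower numbers for stronger inhibition), compound 1 gives the lowest of the three numbers; compound 3 stands nearest, and compound 2 furthest. The two steps away from compound 1 both change the aromatic ring attached to the shared core: a 5.3-fold higher number from compound 1 to compound 2 (0.72 log units; beyond the scatter) and a 3.4-fold higher number from compound 1 to compound 3 (0.53 log units; beyond the scatter), each a modest rise. Between those two the difference is a 1.6-fold lower number from compound 2 to compound 3 (0.20 log units; within the scatter), within the scatter.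

Compound 4 `Cc1nc(-c2ccccc2)c(C(=O)N2CCN(c3c(C)cccc3C)CC2)o1` differs from compound 1 at the other end of the molecule: 2,6-dimethylphenyl in place of 3-chlorophenyl on an amine nitrogen in a ring. Among the measured compounds shown here, no measured step touches that position, so none bears directly on it; the only precedent is that each change made so far to compound 1 raised the number by a modest amount, which argues for a wide range rather than a direction. Compound 4 is therefore expected to sit somewhat weaker than compound 1, an estimated step of a 2.6-fold higher number from compound 1 to compound 4 (0.41 log units; beyond the scatter). The estimate for compound 4 in this assay is 100 nM, with a range of 25 nM to 400 nM.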

Compound 4, half-maximal inhibitory concentration: 146 nM
Beside the measured number, compound 4's estimate is 1.5-fold (0.16 log units) below it; the range from low to high includes it.
By their numbers in this assay, from the lowest: compound 1; then compounds 3, 4 and 2 (each within the scatter of the next).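

In this assay, the position on the amine nitrogen in a ring proves responsive to the group it carries: 2,6-dimethylphenyl in place of 3-chlorophenyl gives a 3.7-fold higher number from compound 1 to compound 4 (0.57 log units; beyond the scatter), so changes at this end of the molecule, and not only at the aromatic ring attached to the shared core, move the number beyond the scatter. The two groups have the same counts of hydrogen-bond donors and acceptors and neither carries a net charge, so the step arises with those counts unchanged, but the swap removes the chloro and adds two methyl groups at once, and the step cannot be divided between those changes. Nothing available gives a cause for this step.

A plain phenyl, a 3-methylphenyl or a 2-methylphenyl on that nitrogen would help separate those changes. A cyclohexyl there would test whether this position needs an aromatic ring at all.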